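The source may report more compounds than this note shows. Statements on the series, on what has been measured and on what is new or still open speak of the compounds shown alone.

Measured compounds:
- compound 1 `CCCN(CC[C@H]1CC[C@H](NC(=O)c2ccccc2-n2cccn2)CC1)[C@H]1CCc2nc(N)sc2C1` — 2 nM
- compound 2 `CCCN(CC[C@H]1CC[C@H](NC(=O)c2ccc(-n3cccn3)cc2)CC1)[C@H]1CCc2nc(N)sc2C1` — 3 nM

Both compounds were tested in an assay on brain for displacement of a labelled ligand from D(3) dopamine receptor (Rattus norvegicus); on this read-out higher numbers stand for weaker inhibition and lower numbers for stronger inhibition. Compound 1 gives 2 nM and compound 2 gives 3 nM. Compound 2 has the larger of the two numbers, but the step of a 1.5-fold higher number from compound 1 to compound 2 (0.18 log units; within the scatter) means the two cannot be told apart.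

Compound 3 `CCCN(CC[C@H]1CC[C@H](NC(=O)c2ccc(-c3noc(C4CC4)n3)cc2)CC1)[C@H]1CCc2nc(N)sc2C1` has not yet been measured. It differs from compound 2 in one place: 5-cyclopropyl-1,2,4-oxadiazol-3-yl in place of 1H-pyrazol-1-yl on an aromatic carbon. Among the compounds with values here, the only step measured so far, a 1.5-fold higher number from compound 1 to compound 2 (0.18 log units; within the scatter), concerns moving the pyrazole around the ring rather than replacing it, so it bears on this change only loosely. Nothing shows how the ring at this position is tolerated when it is exchanged for a bigger group. The expectation is therefore a modest weakening at most, a 2.0-fold higher number from compound 2 to compound 3 (0.30 log units; within the scatter), with wide uncertainty. For compound 3 the estimate is 6 nM, within a range of 1.5 nM to 25 nM.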

Compound 3, inhibition constant: 3.5 nM
The estimate for compound 3 lay 1.7-fold (0.23 log units) above the measured number; low and high end bracket the measured number.
By their numbers in this assay, from the lowest: compounds 1, 2 and 3 (each within the scatter of the next).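

In this assay, putting the 5-cyclopropyl-1,2,4-oxadiazol-3-yl group in place of the smaller 1H-pyrazol-1-yl group gives a 1.2-fold higher number from compound 2 to compound 3 (0.07 log units; within the scatter), so the two compounds cannot be told apart. The earlier pair only moved the pyrazole around the ring, whereas this pair shows that the group para to a large group can be exchanged for one with more heavy atoms and an added three-membered carbon ring without a change beyond the scatter. Nothing available gives a reason for this result.

As far as these compounds go, both groups compared here are built on a five-membered aromatic ring, so it remains open whether a simple amine or a carboxylic acid in the same place would also keep the number in this range. From the compounds shown here alone, it is also open whether a longer carbon chain would do so.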